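The source may report more compounds than this note shows. Statements on the series, on what has been measured and on what is new or still open speak of the compounds shown alone.

In an ADME assay on MOLT-3 cells (Homo sapiens) for cytotoxicity, with a stated time of 7 days (on this read-out lower numbers stand for higher toxicity in this test and higher numbers for lower toxicity in this test), compound 1 `C=CCOc1nc(N)nc2c1ncn2/C=C1/CC1(CO)CO` gives only a limit, > 20000 nM, so its toxicity lies beyond what this test resolves. Compound 2 `COCCOc1nc(N)nc2c1ncn2/C=C1/CC1(CO)CO` likewise returns a limit, > 20000 nM. Compound 3 `Nc1nc(NC2CC2)c2ncn(/C=C3/CC3(CO)CO)c2n1` also stops at a limit, > 20000 nM. Within the data shown here, because of the limit of > 20000 nM in this assay, at which 3 of the 3 values shown sit, none of the measured steps can be sized: the step that the two limits leave unreadable from compound 1 to compound 2, the step that the two limits leave unreadable from compound 1 to compound 3 and the step that the two limits leave unreadable from compound 2 to compound 3 all remain unreadable. Compound 4 `CCCCCCCCSc1nc(N)nc2c1ncn2/C=C1/CC1(CO)CO` differs from compound 1 by octylsulfanyl in place of allyloxy on an aromatic carbon. The measured steps bear on this change only in that each of them also alters the group on an aromatic carbon of the shared core, and in no case did the value fall below the limit, so neither a size nor a direction can be read from them. The expectation for compound 4 is therefore that this assay again reports a limit or a value near it, which corresponds to an estimated step of a number no higher from compound 1 to compound 4 (the limit leaves the size open). The estimate for compound 4 is 20000 nM, within 4000 nM to 100000 nM.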

Compound 4, half-maximal cytotoxic concentration: > 20000 nM
Compound 4: a limit, no number (the forecaster's own chance of this, stated with the estimate: 60%); the middle value lies on the limit itself.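

Among these compounds, compound 4 also gives only a limit, so no step between it and compound 1, compound 2 or compound 3 can be read: the limit of > 20000 nM in this assay, at which 4 of the 4 values shown sit. The compounds shown leave open whether changing the group on this aromatic carbon alters the result in this assay at all.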